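Two limit values and a dechlorinated analogue

The source may hold more compounds than are shown below. What is called first, only, known or untested is meant among the compounds shown, and "the series" means these compounds.

Compound 1, `Nc1nccc(Nc2cc(Cl)cc(Cl)c2)n1`: in an assay on cells for inhibition of S-adenosylmethionine decarboxylase proenzyme (Homo sapiens), read by mass spectrometry, at pH 7.2 (on this read-out higher numbers stand for weaker inhibition and lower numbers for stronger inhibition), compound 1 reaches only the limit > 180000 nM.
Compound 2, `Cc1cc(Nc2cc(Cl)cc(S(F)(F)(F)(F)F)c2)nc(N)n1`: in this assay compound 2 likewise reaches only the limit > 180000 nM.

Within the data shown here, compound 2 therefore stands at no number; the only evidence is the limit of > 180000 nM in this assay, at which 2 of the 2 values shown sit, and no step between measured compounds can be read. Compound 3, `Cc1cc(Nc2cccc(S(F)(F)(F)(F)F)c2)nc(N)n1`, differs from compound 2 by hydrogen in place of chloro on an aromatic carbon. With both measured compounds at the limit, no step beyond the scatter is expected in this assay, and a limit is again the likely report. The expected step is a step that the limit leaves unreadable from compound 2 to compound 3. For compound 3 the estimate is 200000 nM, within 90000 nM to 450000 nM.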

Compound 3, half-maximal inhibitory concentration: > 180000 nM
Compound 3 gave a limit, no number; the forecaster's own chance of this, stated with the estimate: 85%; the middle value is on the limit's open side.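

Compound 2 and compound 3 both stop at a limit in this assay, so no step can be read between them: the limit of > 180000 nM in this assay, at which 3 of the 3 values shown sit.

The compounds shown leave open whether any change to this series gives a measurable inhibition value.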